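Methyl in place of methoxy on compound 2

A few compounds are considered here, and "the series" means these few. Any claim that something is new, unique, unknown or untested is made for them only; others in the source may bear on it.

Compound 1 `COc1ccc(-c2cnc(NC(=O)c3ccc(F)cc3)n2Cc2ccccc2)cc1` reads > 100000 nM as a limit
Compound 2 `COc1cccc(-c2cnc(NC(=O)c3ccc(F)cc3)n2C)c1` reads > 100000 nM as a limit
Compound 3 `O=C(Nc1ncc(-c2ccccc2)o1)c1ccc(Cl)cc1` reads 10000 nM as a number

In a toxicity assay on THP-1 cells (Homo sapiens) for inhibition (a lower number here means that less compound is tolerated, a higher number that more compound is tolerated), compound 2 has no number, only the limit > 100000 nM as its reading. It stands with compound 1 at the top of the measurable range (the limit of > 100000 nM in this assay, at which 2 of the 3 values shown sit). Among the measured compounds shown here, compound 3 gives the only true number in the set, 10000 nM as measured.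

Compound 4 `Cc1cccc(-c2cnc(NC(=O)c3ccc(F)cc3)n2C)c1` has not yet been measured. It keeps the core of compound 2 and changes one group (methyl in place of methoxy on an aromatic carbon), with methyl in place of methoxy on an aromatic carbon, so that 3-methoxyphenyl becomes 3-methylphenyl.

For the measured compounds named here, no measured pair in the set shows what this change does. The expectation rests on compound 2 reading > 100000 nM as a limit. A step of a number no higher from compound 2 to compound 4 (the limit leaves the size open) is expected to stay within the usual scatter, with neither direction favoured. Compound 4 is expected to read close to that same limit, with an estimate of 100000 nM and a range from 40000 nM to 200000 nM for the measurement.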

Compound 4, half-maximal cytotoxic concentration: > 100000 nM
Compound 4 gave a limit, no number (the forecaster's own chance of this, stated with the estimate: 80%); the middle value sits exactly at the limit.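

Compound 2 and compound 4 both give only a limit in this assay, so no step from one to the other can be read: the limit of > 100000 nM in this assay, at which 3 of the 4 values shown sit.

The compounds shown leave open what the change from 3-methoxyphenyl to 3-methylphenyl does in this assay, both in size and in direction.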